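The source may report more compounds than this note shows. Statements on the series, on what has been measured and on what is new or still open speak of the compounds shown alone.

Working notes on the series. Going by the values given here, in a functional assay on HUVEC cells (Homo sapiens) for antiproliferative activity, read by MTT assay, with a stated time of 48 h (a lower number here means a stronger inhibitor, a higher number a weaker inhibitor), compound 2 `O=C(Nc1cccc(Cl)c1)Nc1nnc(Sc2ncnc3scc(-c4ccncc4)c23)s1` gives 21000 nM, the second highest of the three numbers so far. Its nearest neighbour is compound 1 `O=C(Nc1ccccc1)Nc1nnc(Sc2ncnc3scc(-c4ccncc4)c23)s1`, which in this assay gives 19300 nM; the furthest is compound 3 `Cc1ccc(NC(=O)Nc2nnc(Sc3ncnc4scc(-c5ccncc5)c34)s2)cc1Cl`, which gives 23200 nM. All three sit within the scatter of one another: a 1.1-fold higher number from compound 1 to compound 2 (0.04 log units; within the scatter), a 1.1-fold higher number from compound 2 to compound 3 (0.04 log units; within the scatter) and a 1.2-fold higher number from compound 1 to compound 3 (0.08 log units; within the scatter) are each too small to count as a change. Every variation of the aryl group on the urea tried so far has left the number where it was.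

Compound 4 `O=C(Nc1ccc(F)cc1)Nc1nnc(Sc2ncnc3scc(-c4ccncc4)c23)s1` is the next member: 4-fluorophenyl in place of 3-chlorophenyl on an amide-type nitrogen. Among the compounds with values here, no measured step covers this exact exchange, but the steps that do exist on the same aryl group, from compound 1 to compound 2 and from compound 2 to compound 3, were all within the scatter. On that footing no step beyond the scatter is expected in this assay, in either direction. Compound 4 is therefore expected to give about 21000 nM, with a range from 10000 nM to 44000 nM. This corresponds to an expected step of no change at the digits printed from compound 2 to compound 4 (within the scatter), which is to say no real movement.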

Compound 4, half-maximal inhibitory concentration: 28300 nM
Compound 4: middle estimate off by 1.3-fold (0.13 log units), on the low side, within the range that was stated.
By their numbers in this assay, from the lowest: compounds 1, 2, 3 and 4 (each within the scatter of the next).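

In this assay, going by these compounds alone, the first fluoro-bearing aryl group on the amide-type nitrogen stays level with both chlorine-bearing groups: a 1.3-fold higher number from compound 2 to compound 4 (0.13 log units; within the scatter) and a 1.2-fold higher number from compound 3 to compound 4 (0.09 log units; within the scatter). The exchange against the unsubstituted phenyl also gives no real change, a 1.5-fold higher number from compound 1 to compound 4 (0.17 log units; within the scatter), so the four aryl groups now shown, carrying chloro, methyl or fluoro, cannot be told apart at this position. No supporting data bear on why this position gives so flat a result.

All the variation shown is confined to halogen- and methyl-bearing phenyl groups, so it remains open whether an amine or a carboxylic acid on the phenyl, or a cyclohexyl in its place, would move the number. As far as these compounds go, the shared core is constant across all four compounds, so what changes there would do also remains open.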